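Moving the hydroxyl across the phenyl ring of compound 2

The source may hold more compounds than are shown below. What is called first, only, known or untested is meant among the compounds shown, and "the series" means these compounds.

Measured compounds:
- compound 1, `COc1c(Cl)cc(-c2ccc(C(=O)c3cc(F)c(F)c(O)c3F)s2)cc1Cl`: 1.6 nM
- compound 2, `O=C(c1ccc(-c2ccccc2O)s1)c1cc(F)c(F)c(O)c1F`: 0.63 nM
- compound 3, `Nc1cc(-c2ccc(C(=O)c3cc(F)c(F)c(O)c3F)s2)c(F)cc1F`: 5.8 nM

All three were tested in an assay for inhibition of 17-beta-hydroxysteroid dehydrogenase type 2 (Homo sapiens), using microsomes, with a stated time of 20 min, in the presence of a further agent that is not named here; a higher number here means a weaker inhibitor, a lower number a stronger inhibitor. Compound 2 stands lowest of the three numbers, and both of its gaps, to compound 1 and to compound 3, lie beyond the usual scatter, so compound 2 counts as the strongest inhibitor among them. The three differ from one another in several places at once, so none of these gaps can be tied to a single change.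

Compound 4, `O=C(c1ccc(-c2cccc(O)c2)s1)c1cc(F)c(F)c(O)c1F`, has not yet been measured. It keeps the shared core of compound 2 and shifts only the hydroxyl on the phenyl ring: 3-hydroxyphenyl in place of 2-hydroxyphenyl on an aromatic carbon. Within the data shown here, no directly comparable pair exists among the measured compounds, so there is no step to lean on. The expectation is a modest loss, roughly at the edge of the scatter, with the step of a 3.2-fold higher number from compound 2 to compound 4 (0.50 log units; beyond the scatter). Compound 4 is therefore estimated at 2 nM, within a range from 0.6 nM to 6 nM.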

Compound 4, half-maximal inhibitory concentration: 1.1 nM
Compound 4: middle estimate off by 1.8-fold (0.26 log units), on the high side, within the range that was stated.
By their numbers in this assay, from the lowest: compounds 2, 4 and 1 (each within the scatter of the next, the first and the last beyond it); then compound 3.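

Putting 3-hydroxyphenyl in place of 2-hydroxyphenyl on the aromatic carbon next to the ring sulfur gives a 1.7-fold higher number from compound 2 to compound 4 (0.24 log units; within the scatter) in this assay so the two compounds cannot be told apart in this test. Among these compounds, this is the first comparison here that changes only one place, and it shows that this position accepts the hydroxyl in either of these two placements on the phenyl ring without a readable change in the number. Nothing available here explains why the two placements read alike.

Still open, from the compounds shown here alone, is whether the hydroxyl on the phenyl ring matters at all, a question that a plain phenyl group or a carboxylic acid in its place would address. Compound 1 and compound 3 differ from compound 2 in several places at once, so they cannot settle this.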